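A few compounds are considered here, and "the series" means these few. Any claim that something is new, unique, unknown or untested is made for them only; others in the source may bear on it.

Measured so far:
compound 1 `COc1cccc(OC)c1C(=O)Nc1c[nH]nc1C(=O)N[C@H]1CC[C@H](O)CC1` — 34000 nM
compound 2 `CO[C@H]1CC[C@H](NC(=O)c2n[nH]cc2NC(=O)c2cc(Cl)cc(Cl)c2)CC1` — 13000 nM
compound 3 `CO[C@H]1CC[C@H](NC(=O)c2n[nH]cc2NC(=O)C2CCOCC2)CC1` — > 50000 nM

Of the two compounds that give a number in an ADME assay on MRC5 cells (Homo sapiens) for inhibition, with a stated time of 72 h (a higher number here means that more compound is needed for the effect, a lower number that less compound is needed), compound 1 sits highest; the nearer neighbour is compound 2 at 13000 nM. Compound 3 gives only a limit of the assay, > 50000 nM, so its place among the others cannot be fixed (the limit of > 50000 nM in this assay, at which 1 of the 3 values shown sits). Within the data shown here, the one step that can be read from these three runs from compound 2 to compound 3, an at least 3.8-fold higher number from compound 2 to compound 3 (0.58 log units; beyond the scatter), and it concerns the group on the carbonyl carbon.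

Compound 4 `COc1cccc(OC)c1C(=O)Nc1c[nH]nc1C(=O)NCCCN(C)C` is not yet measured. It differs from compound 1 at a different place: 3-(dimethylamino)propyl in place of 4-hydroxycyclohexyl on an amide-type nitrogen. Among the measured compounds shown here, no measured step touches the group on this amide-type nitrogen, so the step from compound 2 to compound 3 does not bear on it, and there is nothing here to set a direction. The expectation is therefore a step of no particular direction, no change at the digits printed from compound 1 to compound 4 (within the scatter), with wide uncertainty. Compound 4 is estimated at 34000 nM, between 10000 nM and 110000 nM.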

Compound 4, half-maximal effective concentration: > 50000 nM
Compound 4: only a limit was reported (the forecaster's own chance of this, stated with the estimate: 35%); at least 1.4-fold (0.16 log units) between middle value and limit.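

Among these compounds, this is the first measured step at the amide-type nitrogen, since the only earlier step concerned the group on a carbonyl carbon. In this assay, putting 3-(dimethylamino)propyl in place of 4-hydroxycyclohexyl gives an at least 1.4-fold higher number from compound 1 to compound 4 (0.16 log units; that floor lies within the scatter), so nothing shown points to a lower number with this change, although the printed floor does not establish a real rise. Compound 4 gives only a limit of the assay, > 50000 nM, so the full size of the step cannot be read: the limit of > 50000 nM in this assay, at which 2 of the 4 values shown sit.

Compound 4 loses the ring and gains the dimethylamino group in a single change, and the compounds shown do not separate these two parts. Also open, on these data alone, is how a plain cyclohexyl, a longer chain ending in the same amine, or a propyl chain ending in a carboxylic acid would read in this assay.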